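This account rests on a few compounds, and the source may have more. Where it says the series, first, only, none or still open, it means among the compounds named here.

Measured compounds:
- compound 1, `O=C(CNC(=O)c1nn(-c2ccc(F)cc2)c(=O)c2ccccc12)Nc1nc2ccccc2s1`: in an assay on L cells for inhibition of Protein-serine O-palmitoleoyltransferase porcupine (Mus musculus), read by reporter gene assay, with a stated time of 24 h (a lower number here means that less compound is needed, a higher number that more compound is needed for the effect), compound 1 gives > 25000 nM, which is a limit of the assay and not a number.
- compound 2, `COc1ccc2nc(NC(=O)CNC(=O)c3nn(-c4ccc(F)cc4)c(=O)c4ccccc34)sc2c1`: in this assay compound 2 gives 90 nM.
- compound 3, `O=C(CNC(=O)c1nn(-c2ccc(F)cc2)c(=O)c2ccccc12)Nc1nc2ccc(Cl)cc2s1`: in this assay compound 3 gives 25 nM.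

Compound 3 holds the lowest of the two numbers shown; compound 2 sits next to it, separated by a 3.6-fold lower number from compound 2 to compound 3 (0.56 log units; beyond the scatter). Compound 1 sits at the limit (the limit of > 25000 nM in this assay, at which 1 of the 3 values shown sits), and the steps of an at least 270-fold lower number from compound 1 to compound 2 (2.44 log units; beyond the scatter) and an at least 1000-fold lower number from compound 1 to compound 3 (3.00 log units; beyond the scatter) show that a substituent on that aromatic carbon matters greatly.

Compound 4, `Cc1ccc2nc(NC(=O)CNC(=O)c3nn(-c4ccc(F)cc4)c(=O)c4ccccc34)sc2c1`, differs from compound 3 in one place: methyl in place of chloro on an aromatic carbon. Going by the values given here, no measured step swaps methyl for chloro here; the nearest comparison is a 3.6-fold lower number from compound 2 to compound 3 (0.56 log units; beyond the scatter), a modest step between two substituted analogues, while the large steps start from the unsubstituted compound 1. The expectation in this assay is therefore a step of a 1.6-fold higher number from compound 3 to compound 4 (0.20 log units; within the scatter), small and within or near the scatter. Compound 4 is estimated at 40 nM, with a range from 15 nM to 120 nM.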

Compound 4, half-maximal effective concentration: 100 nM
Estimate against measurement, compound 4: 2.5-fold (0.40 log units) below, and the stated range covers the measured number.
By their numbers in this assay, from the lowest: compound 3; then compounds 2 and 4 (each within the scatter of the next). At a limit, above all of these: compound 1.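

In this assay, replacing chloro with methyl at this position gives a change beyond the scatter (a 4.0-fold higher number from compound 3 to compound 4 (0.60 log units; beyond the scatter)), so the gain over the unsubstituted compound 1 is not the same for every substituent. Methyl and methoxy cannot be told apart here (a 1.1-fold higher number from compound 2 to compound 4 (0.05 log units; within the scatter)), which leaves chloro, in compound 3, alone with the lowest number of the series. A third substituent now clears the limit of compound 1 (an at least 250-fold lower number from compound 1 to compound 4 (2.39 log units; beyond the scatter)), a step that rests on a limit of the assay and not on a number: the limit of > 25000 nM in this assay, at which 1 of the 4 values shown sits.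

The compounds shown leave open how fluoro, bromo, trifluoromethyl or an amine at this position would compare with chloro. They also leave open whether this order of chloro, methyl and methoxy holds when the rest of the shared core changes.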